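Swapping a Methyl for Methanesulfonamido on a Shared Core

A few compounds are considered here, and "the series" means these few. Any claim that something is new, unique, unknown or untested is made for them only; others in the source may bear on it.

Three compounds have been measured so far:
- Compound 1 `O=C(Nc1cccc(-c2ccco2)c1)C1CCCN(C(=O)c2cc(C(F)(F)F)cc(C(F)(F)F)c2)C1`: in an ADME assay on PC-3 cells (Homo sapiens) for cytotoxicity, read by WST assay, tested at 100 uM (a lower number here means less inhibition, a higher number more inhibition at the concentration tested (going by the name of the read-out)), compound 1 gives 0%.
- Compound 2 `Cc1cccc(C(=O)N2CCCC(C(=O)Nc3ccc(Cl)cc3)C2)c1`: compound 2 gives 0%.
- Compound 3 `CC(C)(C)OC(=O)c1cccc(NC(=O)C2CCCN(C(=O)c3cc(C(F)(F)F)cc(C(F)(F)F)c3)C2)c1`: compound 3 gives 0%.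

Compound 2 stands level with compounds 1 and 3 at the digits shown; all three sit at the same reading, within the usual scatter. For the measured compounds named here, the one step measured directly, no change at the digits printed from compound 1 to compound 3 (within the scatter), also shows no change, so a replacement on an aromatic carbon of the shared core left the read-out where it was.

Compound 4 `CS(=O)(=O)Nc1cccc(C(=O)N2CCCC(C(=O)Nc3ccc(Cl)cc3)C2)c1` differs from compound 2 in one place: methanesulfonamido in place of methyl on an aromatic carbon. Going by the values given here, no measured step involves a methanesulfonamido group, so the comparison rests on the general picture, in which every compound and every step so far shows no inhibition beyond the scatter. The step from compound 2 to compound 4 is therefore expected to be flat, no change at the digits printed from compound 2 to compound 4 (within the scatter). For compound 4 the expected value is 0%, with a range from 0% to 12%.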

Compound 4, a percentage reported as inhibition, at one concentration (the size of the read-out at that concentration, not a potency): 3%
Compound 4: middle estimate off by 3 percentage points, on the low side; low and high end bracket the measured number.
By their numbers in this assay, from the lowest: compounds 1, 2, 3 and 4 (each within the scatter of the next).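

Replacing methyl with methanesulfonamido on this aromatic carbon, meta to a large group, gives a number 3 percentage points higher from compound 2 to compound 4 (within the scatter) in this assay. This change is larger than a swap of one small group for another: the new group adds heavy atoms, including nitrogen, sulfur and oxygen, along with a hydrogen-bond donor and hydrogen-bond acceptors, yet the reading stays within the usual scatter. Nothing available explains why the reading stays there.

On these data alone, whether an amine, a carboxylic acid or a longer chain on this same aromatic carbon would also leave the reading level with compound 2 remains open. As far as these compounds go, it is also open whether methanesulfonamido would give the same flat result at other places on the shared core.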